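Swapping the methoxyphenyl arm: a benzofuran analogue's solubility

The source may report more compounds than this note shows. Statements on the series, on what has been measured and on what is new or still open speak of the compounds shown alone.

compound 1 `CNC(=O)c1cc(C(=O)NC2CC2)cn(Cc2ccc(OC)cc2)c1=O`: 263 ug/mL
compound 2 `CNC(=O)c1cc(C(=O)NC2CC2)cn(Cc2cccc3[nH]ccc23)c1=O`: 17 ug/mL

In a physicochemical assay for solubility, read by HPLC, in simulated intestinal fluid, with a stated time of 16 h, tested at 125 ug/mL (a higher number here means a more soluble compound, a lower number a less soluble compound), compound 1 stands highest of the two measured numbers, with 263 ug/mL, while compound 2 gives 17 ug/mL. Going by the values given here, the one measured step, a 15-fold lower number from compound 1 to compound 2 (1.19 log units; beyond the scatter), is large and downward. Compound 3 `CNC(=O)c1cc(C(=O)NC2CC2)cn(Cc2cccc3occc23)c1=O` differs from compound 1 by 1-benzofuran-4-yl in place of 4-methoxyphenyl on a saturated chain carbon bound to an aromatic nitrogen. Because that step a 15-fold lower number from compound 1 to compound 2 (1.19 log units; beyond the scatter) also replaced 4-methoxyphenyl with a fused aromatic group in the same place, a downward step beyond the scatter is expected here as well, perhaps somewhat smaller. Compound 3 is estimated at 30 ug/mL, within 10 ug/mL to 90 ug/mL. That expectation corresponds to an 8.8-fold lower number from compound 1 to compound 3 (0.94 log units; beyond the scatter).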

Compound 3, solubility: 74 ug/mL
For compound 3 the middle estimate is 2.5-fold (0.39 log units) below the measured one, and the stated range covers the measured number.
By their numbers in this assay, from the lowest: compound 2; then compound 3; then compound 1.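

Replacing 4-methoxyphenyl with 1-benzofuran-4-yl on a saturated chain carbon bound to an aromatic nitrogen gives a 3.6-fold lower number from compound 1 to compound 3 (0.55 log units; beyond the scatter) in this assay, so a fused aromatic group here need not bring the number as low as in compound 2. Exchanging 1H-indol-4-yl for 1-benzofuran-4-yl gives a 4.4-fold higher number from compound 2 to compound 3 (0.64 log units; beyond the scatter), so the two fused groups are not interchangeable at this place. No available evidence accounts for that gap. On these data alone, whether a group carrying an amine or a carboxylic acid at this place would lift the number beyond that of compound 1 remains open.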